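This account rests on a few compounds, and the source may have more. Where it says the series, first, only, none or still open, it means among the compounds named here.

Compound 1 `Cc1ccc(-c2ccc(C(=O)Nc3ccc(Oc4ccnc5[nH]ccc45)cc3)nc2)cc1`, compound 2 `CCc1ccc(-c2ccc(C(=O)Nc3ccc(Oc4ccnc5[nH]ccc45)cc3)nc2)cc1`, compound 3 `COc1ccc(-c2ccnc(C(=O)Nc3ccc(Oc4ccnc5[nH]ccc45)cc3)c2)cc1` and the not yet measured compound 4 `O=C(Nc1ccc(Oc2ccnc3[nH]ccc23)cc1)c1cc(-c2ccc(Cl)cc2)ccn1` share one core and differ only in the outer aryl ring. In a functional assay on A549 cells (Homo sapiens) for cytotoxicity, read by MTT assay, with a stated time of 72 h (on this read-out higher numbers stand for weaker inhibition and lower numbers for stronger inhibition), compound 1 reaches only the limit of the measurement, > 10000 nM. Compound 2 likewise gives only a limit, > 10000 nM. Among the measured compounds shown here, the single step that can be drawn between two measured compounds, a step that the two limits leave unreadable from compound 1 to compound 2, has no readable size, as the limit of > 10000 nM in this assay, at which 2 of the 3 values shown sit, shows. For the measured compounds named here, compound 3 is the only compound with a number in this assay, 6970 nM. The values of compound 1 and compound 2 are limits, so no order between compound 3 and those two can be stated.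

Compound 4 differs from compound 3 by chloro in place of methoxy on an aromatic carbon. Going by the values given here, no measured step concerns this kind of change, and the one step that was measured has no readable size, so the data give neither a direction nor a magnitude for it. The expected step is a 1.0-fold higher number from compound 3 to compound 4 (0.00 log units; within the scatter), which is no more than the usual scatter. In this assay compound 4 is therefore estimated at 7000 nM, with a range from 2500 nM to 20000 nM, and a real chance that only a limit is reported.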

Compound 4, half-maximal inhibitory concentration: 4310 nM
Beside the measured number, compound 4's estimate is 1.6-fold (0.21 log units) above it; low and high end bracket the measured number.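

Among the compounds shown here, compound 3 and compound 4 give the first step in this set that can be read: in this assay, chloro in place of methoxy, on a six-membered aromatic ring of carbon only and para to a large group, gives a 1.6-fold lower number from compound 3 to compound 4 (0.21 log units; within the scatter). At this place, then, 4-methoxyphenyl and 4-chlorophenyl cannot be told apart in this assay, although methoxy has 2 heavy atoms and 1 hydrogen-bond acceptor and chloro has 1 heavy atom and 0 hydrogen-bond acceptors. Compound 1 and compound 2 cannot add to this comparison, and the step between them cannot be read: the limit of > 10000 nM in this assay, at which 2 of the 4 values shown sit.

Going by these compounds, it remains open whether a different group at this place, such as an amine, a carboxylic acid or a longer chain, would give a step beyond the scatter. On these data alone, it is also open whether the change from 4-methoxyphenyl to 4-chlorophenyl would give a similar step on the core of compound 1.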